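Series notes: methyl in place of dimethylamino

The source may report more compounds than this note shows. Statements on the series, on what has been measured and on what is new or still open speak of the compounds shown alone.

Compound 3 `CN(C)c1ccc(C2CC(c3ccc(Br)cc3)=NN2c2nc3ccc(S(N)(=O)=O)cc3s2)cc1` gives 14% in a functional assay on the whole organism (strain Wistar) for inhibition, with Rattus norvegicus as the target, read by paw edema, with stated times of 1 h and 5 h, at a dose of 20 mg/kg by the oral route; a lower number here means less inhibition, a higher number more inhibition at the dose given (going by the name of the read-out). It stands level with compound 1 `NS(=O)(=O)c1ccc2nc(N3N=C(c4ccc(Br)cc4)CC3c3ccc(Cl)cc3)sc2c1` at 14% and with compound 2 `COc1ccc(C2CC(c3ccc(Br)cc3)=NN2c2nc3ccc(S(N)(=O)=O)cc3s2)cc1` at 14%. The measured steps of no change at the digits printed from compound 1 to compound 2 (within the scatter), no change at the digits printed from compound 1 to compound 3 (within the scatter) and no change at the digits printed from compound 2 to compound 3 (within the scatter) all lie within the scatter. Compound 4 `Cc1ccc(C2CC(c3ccc(Br)cc3)=NN2c2nc3ccc(S(N)(=O)=O)cc3s2)cc1` differs from compound 3 by methyl in place of dimethylamino on an aromatic carbon. Each measured step exchanged the group on the same aromatic carbon of the same ring and left this assay unmoved, and the present exchange is of the same kind. A step of no size beyond the scatter is therefore expected, no change at the digits printed from compound 3 to compound 4 (within the scatter). Compound 4 is estimated at 14%, with a range from 4% to 24%.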

Compound 4, a percentage reported as inhibition, in the whole organism at one dose (the size of the read-out at that dose, not a potency): 14%
Beside the measured number, compound 4's estimate shows no gap at the digits printed; measured number inside the range.
By their numbers in this assay, from the lowest: compounds 1, 2, 3 and 4 (each within the scatter of the next).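

In this assay, the change to methyl at this place shows no change at the digits printed from compound 3 to compound 4 (within the scatter), with no change at the digits printed from compound 2 to compound 4 (within the scatter) and no change at the digits printed from compound 1 to compound 4 (within the scatter). Methyl extends the set on this aromatic carbon, para to a large group, to four groups that all lie within the scatter of one another: chloro, methoxy, dimethylamino and methyl. The exchange of dimethylamino for the smaller methyl, which also removes a hydrogen-bond acceptor, leaves the reading unmoved.

On these data alone, whether a carboxylic acid or a longer chain here would move the reading stays open. Nothing measured on these compounds accounts for this unmoved reading.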